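A Benzyl Group Tried in Place of an Aryl Group

The source may hold more compounds than are shown below. What is called first, only, known or untested is meant among the compounds shown, and "the series" means these compounds.

Three compounds have been measured in a functional assay on BJAB cells (Homo sapiens) for antiproliferative activity, with a stated time of 4 days; on this read-out lower numbers stand for an effect already at smaller amounts and higher numbers for an effect only at larger amounts of compound:
Compound 1 `Cc1ccc(-c2c(C)nn(-c3nc(-c4ccc(Cl)c(Cl)c4)c(SC(C)C)s3)c2C(=O)O)cc1` gives 3800 nM.
Compound 2 `COc1cc(C#N)cc(-c2c(C)nn(-c3nc(-c4ccc(Cl)c(Cl)c4)c(SC(C)C)s3)c2C(=O)O)c1` gives 5200 nM.
Compound 3 `COc1ccc(C)cc1-c1c(C)nn(-c2nc(-c3ccc(Cl)c(Cl)c3)c(SC(C)C)s2)c1C(=O)O` gives 9500 nM.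

Compound 3 shows the highest number of the three. Its gap to compound 2, a 1.8-fold higher number from compound 2 to compound 3 (0.26 log units; within the scatter), lies within the scatter, whereas the gap to compound 1, a 2.5-fold higher number from compound 1 to compound 3 (0.40 log units; beyond the scatter), lies beyond it.

Compound 4 `Cc1nn(-c2nc(-c3ccc(Cl)c(Cl)c3)c(SC(C)C)s2)c(C(=O)O)c1Cc1ccccc1[N+](=O)[O-]` differs from compound 3 in one place: 2-nitrobenzyl in place of 2-methoxy-5-methylphenyl on an aromatic carbon. Among the measured compounds shown here, no measured step puts a benzyl group at this position; all three exchange one aryl group for another, and the largest of them is a 2.5-fold higher number from compound 1 to compound 3 (0.40 log units; beyond the scatter), the smallest a 1.4-fold higher number from compound 1 to compound 2 (0.14 log units; within the scatter). A step of similar, modest size in this assay is therefore expected, with no clear direction. Compound 4 is estimated at 9000 nM, between 3000 nM and 27000 nM. That estimate means a 1.1-fold lower number from compound 3 to compound 4 (0.02 log units; within the scatter).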

Compound 4, half-maximal effective concentration: 20000 nM
For compound 4 the middle estimate is 2.2-fold (0.35 log units) below the measured one; the range from low to high includes it.
By their numbers in this assay, from the lowest: compounds 1, 2 and 3 (each within the scatter of the next, the first and the last beyond it); then compound 4.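

In this assay, 2-nitrobenzyl on this aromatic carbon gives a higher number than each of the three aryl groups: a 2.1-fold higher number from compound 3 to compound 4 (0.32 log units; beyond the scatter), a 3.8-fold higher number from compound 2 to compound 4 (0.59 log units; beyond the scatter) and a 5.3-fold higher number from compound 1 to compound 4 (0.72 log units; beyond the scatter). The one benzyl group shown thus stretches the spread beyond what the aryl exchanges alone showed. Nothing available accounts for this rise.

Compound 4 alone does not tell whether the higher number goes with the benzyl link or with the nitro group. A plain benzyl group or a 2-aminobenzyl group here would help separate the two.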